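This account rests on a few compounds, and the source may have more. Where it says the series, first, only, none or still open, it means among the compounds named here.

Compound 1 `Cc1c(OCCCCOc2ccc(F)c(C(=O)O)c2)ccc(C(=O)CC2CCCC2)c1O` was tested in an assay on HEK293 cells for positive allosteric modulation of metabotropic glutamate receptor 2 (Rattus norvegicus), read by thallium flux, with a stated time of 2.5 min (on this read-out higher numbers stand for larger maximal responses and lower numbers for smaller maximal responses), where compound 1 gives 81%. Two relatives share its core and differ from it only in the group on a saturated chain carbon bound to a carbonyl carbon: compound 2 `CCCC(=O)c1ccc(OCCCCOc2ccc(F)c(C(=O)O)c2)c(C)c1O`, which in this assay gives 87.5%, and compound 3 `Cc1c(OCCCCOc2ccc(F)c(C(=O)O)c2)ccc(C(=O)CC(C)(C)C)c1O`, which in this assay gives 94.6%. Among these three numbers compound 1 stands lowest; the measured steps were a number 6.5 percentage points higher from compound 1 to compound 2 (within the scatter), a number 13.6 percentage points higher from compound 1 to compound 3 (beyond the scatter) and a number 7.1 percentage points higher from compound 2 to compound 3 (within the scatter). Compound 4 `Cc1c(OCCCCOc2cccc(C(=O)O)c2)ccc(C(=O)CC2CCCC2)c1O` keeps the cyclopentyl group of compound 1 and changes a different part of the molecule: hydrogen in place of fluoro on an aromatic carbon. For the measured compounds named here, none of the measured steps touches this part; all three vary the group on the chain carbon bound to the carbonyl carbon, so they give no direct guidance for this change. With nothing pointing to a shift in this assay, no step beyond the scatter is expected, no change at the digits printed from compound 1 to compound 4 (within the scatter). Compound 4 is therefore estimated to reach 81% in this assay, with a plausible range from 68% to 94%.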

Compound 4, largest response reached (reported as percent of maximum), in percent of the reference or control that the assay uses: 80.6%
For compound 4 the middle estimate is 0.4 percentage points above the measured one; the measured number falls inside the stated range.
By their numbers in this assay, from the lowest: compounds 4, 1, 2 and 3 (each within the scatter of the next, the first and the last beyond it).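

In this assay, hydrogen in place of fluoro turns the 3-carboxy-4-fluorophenyl group into 3-carboxyphenyl and gives a number 0.4 percentage points lower from compound 1 to compound 4 (within the scatter) with the cyclopentyl group kept. So, with this cyclopentyl group in place, the maximal response does not depend on the fluoro at this aromatic carbon, which is ortho to a carboxy group and para to a large group. For the compounds shown here, the earlier compounds varied only the group on the chain carbon bound to the carbonyl carbon, so this is the first reading from the aromatic ring, and no measured result here explains it.

From the compounds shown here alone, whether hydrogen and fluoro also match when the tert-butyl group of compound 3 replaces cyclopentyl remains open. So does the effect of a chloro, methoxy or amino group on this same aromatic carbon.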